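A few compounds are considered here, and "the series" means these few. Any claim that something is new, unique, unknown or untested is made for them only; others in the source may bear on it.

Of the compounds shown here, two from this series have been tested so far in a functional assay on HL-60 cells (Homo sapiens) for antiproliferative activity, with a stated time of 24 h; a higher number here means a weaker inhibitor, a lower number a stronger inhibitor. Compound 1, `NC(=O)c1c(NC(=O)c2ccc(C(F)(F)F)cc2)sc2c1CCN(Cc1c(Cl)cccc1Cl)C2`, gives 10600 nM in this assay. Compound 2, `NC(=O)c1c(NC(=O)c2ccccc2Cl)sc2c1CCN(C(=S)Nc1ccccc1)C2`, gives 5940 nM in this assay. The two values lie within the usual scatter of each other, so neither compound can be called the stronger inhibitor on these numbers; compound 2 simply has the lower of the two, with nothing separating it from compound 1 beyond the scatter.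

The step that follows goes from compound 2 to compound 3, `NC(=O)c1c(NC(=O)c2ccccc2Cl)sc2c1CCN(C(=S)Nc1c(Cl)cccc1Cl)C2`. The change is 2,6-dichlorophenyl in place of phenyl on an amide-type nitrogen. For the measured compounds named here, no comparable pair among the measured compounds shows what such a change does here, so there is no measured step to lean on.

In the absence of any such reference, the step from compound 2 to compound 3 is expected to be small, in either direction, and is estimated as a 1.3-fold lower number from compound 2 to compound 3 (0.12 log units; within the scatter), which does not go beyond the scatter. Compound 3 is therefore estimated at 4500 nM in this assay, with a range from 1500 nM to 15000 nM.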

Compound 3, half-maximal inhibitory concentration: 3950 nM
Estimate against measurement, compound 3: 1.1-fold (0.06 log units) above; low and high end bracket the measured number.
By their numbers in this assay, from the lowest: compounds 3, 2 and 1 (each within the scatter of the next, the first and the last beyond it).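

For the compounds shown here, this pair is the first to differ in one place, and it gives a first reading on the aryl group carried by the amide-type nitrogen whose other neighbour is the thiocarbonyl carbon: in this assay the exchange of phenyl for 2,6-dichlorophenyl gives a 1.5-fold lower number from compound 2 to compound 3 (0.18 log units; within the scatter) and so does not separate the two compounds. Adding two chlorine atoms to this ring therefore leaves the read-out indistinguishable on this single pair, although one pair cannot establish a trend for this position or show how the same change would behave with other groups elsewhere on the shared core. No measurement available here bears on this result.

The compounds shown leave open whether a single chlorine or a methoxy group on this ring, or a cyclohexyl ring or a longer alkyl chain in place of the ring, would move the number beyond the scatter. They also leave open whether a carbonyl in place of the thiocarbonyl would change the reading for this pair.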